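A few compounds are considered here, and "the series" means these few. Any claim that something is new, unique, unknown or untested is made for them only; others in the source may bear on it.

Two compounds of the shared core carry numbers in an assay on membranes from HEK293 cells for displacement of a labelled ligand from adenosine receptor A2b (Homo sapiens), read by scintillation counting, with a stated time of 30 min, tested at 1 uM; on this read-out lower numbers stand for less inhibition and higher numbers for more inhibition at the one concentration tested (going by the name of the read-out). Compound 1 `CC1=C(C(=O)OCc2ccccc2)C(c2ccco2)NC(=S)N1` gives 41%, and compound 2 `COC(=O)C1=C(C)N(C)C(=O)NC1c1ccco1` gives 31%; the two numbers lie within the scatter of each other, so compound 2 stands level with compound 1 and is not separated from it. Compound 3 `CC1=C(C(=O)OC(C)(C)C)C(c2ccco2)NC(=O)N1C` is unmeasured and differs from compound 2 by tert-butyl in place of methyl on an oxygen next to a carbonyl group. Within the data shown here, no measured pair shows this change. The step from compound 2 to compound 3 is expected to be a number 1 percentage points lower from compound 2 to compound 3 (within the scatter), none beyond the scatter. Compound 3 is estimated at 30%, between 10% and 50%.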

Compound 3, a percentage reported as inhibition, at one concentration (the size of the read-out at that concentration, not a potency): 26%
For compound 3 the middle estimate is 4 percentage points above the measured one, and the stated range covers the measured number.
By their numbers in this assay, from the lowest: compounds 3, 2 and 1 (each within the scatter of the next, the first and the last beyond it).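

In this assay the first step read at this position is a number 5 percentage points lower from compound 2 to compound 3 (within the scatter) with tert-butyl in place of methyl on an oxygen next to a carbonyl group. A much larger group on this oxygen therefore leaves the two compounds unseparated, so methoxycarbonyl and tert-butoxycarbonyl stand level here. No measurement bears on the reason for this result.

From the compounds shown here alone, whether a carboxylic acid or a primary amide in place of methoxycarbonyl would separate from compound 2 remains open. A phenyl group on the same oxygen also remains an open case.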